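Methyl to fluoro: expecting little change

The source may hold more compounds than are shown below. What is called first, only, known or untested is meant among the compounds shown, and "the series" means these compounds.

Compound 2 `Cc1ccc(NC(=O)CSC(=S)N[C@H]2CCOC2=O)cc1` gives 93900 nM in a functional assay on EC9706 cells (Homo sapiens) for cytotoxicity, read by MTT assay, with a stated time of 72 h; a higher number here means a weaker inhibitor, a lower number a stronger inhibitor. For the measured compounds named here, its number is the lower of the two measured so far, yet compound 1 `O=C(CSC(=S)N[C@H]1CCOC1=O)Nc1cccc(Cl)c1` with 107000 nM sits within the scatter of it, the step being a 1.1-fold lower number from compound 1 to compound 2 (0.06 log units; within the scatter). Compound 3 `O=C(CSC(=S)N[C@H]1CCOC1=O)Nc1ccc(F)cc1` differs from compound 2 by fluoro in place of methyl on an aromatic carbon. Going by the values given here, only that one measured step bears on this change; it altered the group on the same ring and moved nothing beyond the scatter, so compound 3 is expected to show a step of a 1.1-fold higher number from compound 2 to compound 3 (0.03 log units; within the scatter). The estimate for compound 3 is 100000 nM, with a range from 40000 nM to 250000 nM.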

Compound 3, half-maximal inhibitory concentration: 67100 nM
Compound 3: the middle estimate sits 1.5-fold (0.17 log units) above what was measured; the range from low to high includes it.
By their numbers in this assay, from the lowest: compounds 3, 2 and 1 (each within the scatter of the next).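

In this assay, the swap of methyl for fluoro on the aromatic carbon para to a large group gives a 1.4-fold lower number from compound 2 to compound 3 (0.15 log units; within the scatter) and so leaves the number where it was. Replacing 3-chlorophenyl with 4-fluorophenyl gives a 1.6-fold lower number from compound 1 to compound 3 (0.20 log units; within the scatter) and likewise separates the two compounds by no more than ordinary repeat variation. So far, three different substituted phenyl groups on the amide nitrogen cannot be told apart in this measurement. No supporting measurement bears on this result.

As far as these compounds go, it remains open whether an amine or a carboxylic acid at this ring position would move the number beyond the scatter.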